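Swapping a diaryl ether for a thioether on the shared core

The compounds below may be only part of what the source reports. "The series", "measured", "known", "first", "only" and "open" are said of these compounds alone.

Compound 1 `Nc1cc(N)c2nc(-c3ccccc3)c(Oc3ccc(Cl)c(Cl)c3)nc2c1` is tested in a functional assay on IGROV-1 cells (Homo sapiens) for inhibition, read by sulforhodamine B assay, with a stated time of 48 h (a lower number here means a stronger inhibitor of growth, a higher number a weaker inhibitor of growth), and gives 11500 nM. For the measured compounds named here, it is the only compound here with a real number: the other value is a limit. Compound 2 `CCOC(=O)[C@H](CCC(=O)O)NC(=O)c1ccc(CNc2nc3cc(N)cc(N)c3nc2-c2ccccc2)cc1` shows only a limit in this assay, < 100000 nM, which means the assay reported no number for it, as the limit of < 100000 nM in this assay, at which 1 of the 2 values shown sits, records. Compound 3 `Nc1cc(N)c2nc(-c3ccccc3)c(Sc3ccc(F)cc3)nc2c1` has not yet been measured. It differs from compound 1 by (4-fluorophenyl)sulfanyl in place of 3,4-dichlorophenoxy on an aromatic carbon. Going by the values given here, no measured pair of compounds here makes the same change, so the size of this step is not known from the data. The step from compound 1 to compound 3 is expected to be small, a 1.3-fold higher number from compound 1 to compound 3 (0.12 log units; within the scatter), within or close to the usual scatter, with no firm direction. Compound 3 is therefore estimated to give 15000 nM in this assay, in the range 4000 nM to 60000 nM.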

Compound 3, concentration for 50% growth inhibition: 25100 nM
Beside the measured number, compound 3's estimate is 1.7-fold (0.22 log units) below it; low and high end bracket the measured number.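

In this assay, putting (4-fluorophenyl)sulfanyl in place of 3,4-dichlorophenoxy gives a 2.2-fold higher number from compound 1 to compound 3 (0.34 log units; beyond the scatter), the first measured size for any change at this aromatic carbon next to the ring nitrogen. The step is modest, and compound 3 still gives a real number, 25100 nM, though the swap changes both the linking atom and the halogens on the ring, so this step belongs to the whole swap and not to any single atom. Nothing given here explains the step.

The separate contributions of the linking atom and the halogens remain open, since no pair shown changes only one of them. Going by these compounds, it is also open how a smaller or quite different group at this position, such as methoxy or morpholine, would compare.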